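A few compounds are considered here, and "the series" means these few. Any claim that something is new, unique, unknown or untested is made for them only; others in the source may bear on it.

Of the compounds shown here, three have been measured so far in an ADME assay on HEL cells (Homo sapiens) for cytotoxicity, read by cell counting, with a stated time of 3 days; a higher number here means that more compound is tolerated, a lower number that less compound is tolerated. Compound 1 `O=c1[nH]c(=O)n([C@H]2C[C@H](O)[C@@H](CO)O2)cc1-c1cn(-c2c(F)cccc2F)nn1` gives >= 10000 nM, which is a limit of the assay rather than a number. Compound 2 `O=c1[nH]c(=O)n([C@H]2C[C@H](O)[C@@H](CO)O2)cc1-c1cn(-c2cc(F)cc(F)c2)nn1` gives 220000 nM. Compound 3 `O=c1[nH]c(=O)n([C@H]2C[C@H](O)[C@@H](CO)O2)cc1-c1cn(-c2ccc(Cl)cc2)nn1` gives > 240000 nM, again a limit and not a number. Compound 3 thus sits at the limit of > 240000 nM in this assay, at which 1 of the 3 values shown sits, and of the three values shown one more is a limit, namely (the limit of >= 10000 nM in this assay, at which 1 of the 3 values shown sits). The step that the limit leaves unreadable from compound 1 to compound 2 is not readable. The step that the two limits leave unreadable from compound 1 to compound 3 is not readable either. Among the measured compounds shown here, the only readable step is an at least 1.0-fold higher number from compound 2 to compound 3 (0.03 log units; that floor lies within the scatter), and its floor lies within the scatter.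

Compound 4 `O=c1[nH]c(=O)n([C@H]2C[C@H](O)[C@@H](CO)O2)cc1-c1cn(-c2ccc(Oc3ccccc3)cc2)nn1` differs from compound 3 in one place: phenoxy in place of chloro on an aromatic carbon. For the measured compounds named here, no measured step involves a phenoxy group, so the measured pairs bear on it only in showing that the compounds shown sit at or near the upper reach of this assay. For compound 4 the expected step is a number no higher from compound 3 to compound 4 (the limit leaves the size open), none beyond the scatter. Compound 4 is therefore estimated at 240000 nM, within 80000 nM to 260000 nM, with a real chance that only a limit is reported.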

Compound 4, minimum cytotoxic concentration: 130000 nM
Estimate against measurement, compound 4: 1.8-fold (0.27 log units) above; low and high end bracket the measured number.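

Phenoxy in place of chloro gives the first step at this aromatic carbon in this assay, and it is only a floor: an at least 1.8-fold lower number from compound 3 to compound 4 (0.26 log units; that floor lies within the scatter). Compound 4 gives 130000 nM, a number and not a limit, so with phenoxy, which brings a six-membered aromatic ring to this position, the series yields a value that can be read directly. The value of compound 3 is a limit, and the true size of the step stays hidden behind it: the limit of > 240000 nM in this assay, at which 1 of the 4 values shown sits.

From the compounds shown here alone, whether the real step lies within or beyond the scatter remains open. Also open, going by these compounds, is how a group of another kind on this aromatic carbon, such as an amine, a carboxylic acid or a longer alkyl chain, would read in this assay.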